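The compounds below may be only part of what the source reports. "The series", "measured", "known", "first", "only" and "open" are said of these compounds alone.

In a functional assay (blood) for inhibition, with Homo sapiens as the target (a lower number here means a stronger inhibitor, a higher number a weaker inhibitor), compound 1 `CC(C)/C(=N\O)c1ccc(Sc2cc(F)cc(C3CCOCC3)c2)cc1` gives 300 nM. Among the measured compounds shown here, compound 2 `C/C(=N\OCCSc1nnnn1C)c1ccc(Sc2cc(F)cc(C3CCOCC3)c2)cc1` gives 120 nM in this assay, the lower of the two numbers measured so far; its gap to compound 1 lies beyond the usual scatter. Compound 3 `CC(=O)O/N=C(\C)c1ccc(Sc2cc(F)cc(C3CCOCC3)c2)cc1` has not yet been measured. Its change from compound 2 is acetyl in place of 2-((1-methyl-1H-tetrazol-5-yl)sulfanyl)ethyl on an oxygen. For the measured compounds named here, no step between two measured compounds matches this change, so the expectation rests on the two measured values alone. A modest step toward a higher number is expected: a 2.1-fold higher number from compound 2 to compound 3 (0.32 log units; beyond the scatter). For compound 3 the estimate in this assay is 250 nM, with a range of 80 nM to 800 nM.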

Compound 3, half-maximal inhibitory concentration: 50 nM
For compound 3 the middle estimate is 5.0-fold (0.70 log units) above the measured one; the whole stated range lies above it.
By their numbers in this assay, from the lowest: compound 3; then compound 2; then compound 1.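

In this assay, acetyl in place of 2-((1-methyl-1H-tetrazol-5-yl)sulfanyl)ethyl on the oxygen gives a 2.4-fold lower number from compound 2 to compound 3 (0.38 log units; beyond the scatter), so the tetrazole ring is not needed on this oxygen for a low number. Changing the whole group on the aromatic carbon gives a 6.0-fold lower number from compound 1 to compound 3 (0.78 log units; beyond the scatter), leaving compound 3 with the lowest number of the series. No measurement shown accounts for either step. From the compounds shown here alone, whether the carbonyl matters remains open, since a simple methyl or a longer chain such as propanoyl on this oxygen would test it. Going by these compounds, how an amine at the end of the chain would compare is also open.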